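Piperidine methylation in the corticotropin-releasing factor series

The source may hold more compounds than are shown below. What is called first, only, known or untested is meant among the compounds shown, and "the series" means these compounds.

Measured compounds:
- compound 1 `CCN(Cc1ccccc1)Cc1c(C(F)(F)F)nc2n(-c3c(C)cc(C)cc3C)c(Cl)cn12`: 350 nM
- compound 2 `Cc1cc(C)c(-n2c(Cl)cn3c(CN4CCCCC4)c(C(F)(F)F)nc23)c(C)c1`: 1200 nM

In an assay on cells for displacement of a labelled ligand from corticotropin-releasing factor receptor 1 (Homo sapiens), with a stated time of 100 min (on this read-out higher numbers stand for weaker inhibition and lower numbers for stronger inhibition), compound 1 gives 350 nM and compound 2 gives 1200 nM. For the measured compounds named here, the one step between them, a 3.4-fold higher number from compound 1 to compound 2 (0.54 log units; beyond the scatter), runs against compound 2, which therefore holds the highest of the two numbers seen in this assay, with compound 1 as its nearest neighbour.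

Compound 3 `Cc1cc(C)c(-n2c(Cl)cn3c(CN4CCC(C)CC4)c(C(F)(F)F)nc23)c(C)c1` differs from compound 2 only by methyl in place of hydrogen on a saturated ring carbon. Going by the values given here, no measured pair shows this change; the only step available, a 3.4-fold higher number from compound 1 to compound 2 (0.54 log units; beyond the scatter), concerns the amine group as a whole, not a substituent on the piperidine ring, so it bears on the new step only loosely. With the amine set to piperidin-1-yl in both compounds, and only a methyl added on a saturated ring carbon, a step of the order of the scatter is expected in this assay, with a slight lean toward a lower number given that the larger amine of compound 1 gave 350 nM. For compound 3 the expected step is a 1.3-fold lower number from compound 2 to compound 3 (0.12 log units; within the scatter), giving an estimate of 900 nM, between 300 nM and 2700 nM.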

Compound 3, inhibition constant: 3200 nM
Estimate against measurement, compound 3: 3.6-fold (0.55 log units) below, and the stated range ends below it.
By their numbers in this assay, from the lowest: compound 1; then compound 2; then compound 3.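

In this assay, putting methyl on the saturated ring carbon three ring bonds from the ring nitrogen gives a 2.7-fold higher number from compound 2 to compound 3 (0.43 log units; beyond the scatter), so this first substituent on the piperidine ring moves the number upward, beyond the scatter, and the ring position is not indifferent to this change. Compound 1 remains the lowest of the series, and the change from its benzyl(ethyl)amino group to 4-methylpiperidin-1-yl gives a 9.1-fold higher number from compound 1 to compound 3 (0.96 log units; beyond the scatter), so the added methyl widens the distance from the open-chain amine instead of closing it. Nothing available here bears on the reason for this rise.

Going by these compounds, with one substituent at one ring carbon, it remains open whether the upward move is particular to methyl or would also follow from a hydroxyl group, a fluorine atom or a longer chain such as ethyl at the same carbon, and whether methyl on another ring carbon would behave alike. Compound 3 also leaves open whether a benzyl group on the piperidine ring, or a morpholine ring in place of piperidine, would bring the number back toward that of compound 1, which gives 350 nM.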